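Trimming the Biphenyl Arm of Compound 1

The source may report more compounds than this note shows. Statements on the series, on what has been measured and on what is new or still open speak of the compounds shown alone.

Compound 1 `NC1CCC(Nc2nc(NCc3ccc(-c4ccccc4)cc3)c3ncn(C4CCCC4)c3n2)CC1` is one of three compounds built on the same core, differing only in the groups attached to it. In a functional assay on G-361 cells (Homo sapiens) for inhibition, with a stated time of 72 h (on this read-out higher numbers stand for weaker inhibition and lower numbers for stronger inhibition), compound 1 gives 1020 nM. Compound 2 `OC1CCC(Nc2nc(NCc3ccc(-c4ccco4)nc3)c3ncn(C4CCCC4)c3n2)CC1` gives 443 nM, while compound 3 `CC(C)(O)CNc1nc(NCc2ccc(-c3ccco3)nc2)c2ncn(C3CCCC3)c2n1` gives 2100 nM. Compound 1 therefore sits second highest of the three numbers, closest to compound 3 and furthest from compound 2. For the measured compounds named here, the single step measured between two compounds that differ in one place, a 4.7-fold higher number from compound 2 to compound 3 (0.68 log units; beyond the scatter), concerns 2-hydroxy-2-methylpropyl in place of 4-hydroxycyclohexyl on a nitrogen on an aromatic ring, a part of the molecule untouched by the change considered here.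

Compound 4 `Nc1ccccc1CNc1nc(NC2CCC(N)CC2)nc2c1ncn2C1CCCC1` has not yet been measured in this assay. It differs from compound 1 as follows: 2-aminophenyl in place of 4-phenylphenyl on a saturated chain carbon bound to a nitrogen on an aromatic ring. No measured step among these compounds alters this part of the molecule, so there is nothing to indicate the direction of the effect or whether it will exceed the scatter. The expectation is therefore anchored near compound 1 with a wide range. Compound 4 is estimated to show a 1.5-fold higher number from compound 1 to compound 4 (0.17 log units; within the scatter). Compound 4 is expected to give 1500 nM, within a range from 300 nM to 8000 nM.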

Compound 4, half-maximal inhibitory concentration: 2070 nM
The estimate for compound 4 lay 1.4-fold (0.14 log units) below the measured number; the range from low to high includes it.
By their numbers in this assay, from the lowest: compound 2; then compound 1; then compounds 4 and 3 (each within the scatter of the next).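

In this assay, for the compounds shown here, the arm on the saturated chain carbon turns out to matter, since the one change measured there gives a 2.0-fold higher number from compound 1 to compound 4 (0.31 log units; beyond the scatter). Putting 2-aminophenyl in place of 4-phenylphenyl takes away one of the two six-membered aromatic rings and adds one hydrogen-bond donor and one hydrogen-bond acceptor, yet this large change in the arm shifts the number only modestly, and compound 4 still gives a measurable value. Going by these compounds alone, no supporting data point to what lies behind this shift, and the single step alters the size of the arm and adds an amine at the same time, so it cannot tell those two changes apart.

The compounds shown leave open how much of the step goes with the lost ring and how much with the amine, a question that a plain phenyl group on the same carbon would help to settle. Also open, going by these compounds, is whether a hydroxyl or a carboxylic acid in place of that amine would give a different number, and whether the same swap would have a similar size with the 4-hydroxycyclohexyl group of compound 2.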